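The source may report more compounds than this note shows. Statements on the series, on what has been measured and on what is new or still open speak of the compounds shown alone.

Three compounds of one series, all carrying the same core, have been measured in an assay on membranes from lung (Cavia porcellus) for binding affinity to cysteinyl leukotriene receptor (Homo sapiens); a lower number here means a stronger inhibitor, a higher number a weaker inhibitor. Compound 1 `CC(CCc1cccc(OCc2ccc3ccccc3n2)c1)Cc1nnn[nH]1` gives 17 nM in this assay. Compound 2 `O=C(O)CC1CCCC1Cc1ccc(OCc2ccc3ccccc3n2)cc1` gives 100 nM. Compound 3 `CC(CCC(=O)O)Cc1cccc(OCc2ccc3ccccc3n2)c1` gives 140 nM, the highest of the three numbers, although its gap to compound 2 lies within the scatter, so the two cannot be ranked against each other. Among the compounds with values here, the one step between compounds that differ in a single place, an 8.2-fold higher number from compound 1 to compound 3 (0.92 log units; beyond the scatter), exchanges the acid-bearing group on the chain.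

Compound 4 `CC(CCCC(=O)O)c1cccc(OCc2ccc3ccccc3n2)c1` is formed from compound 3 with the same atoms joined differently: 4-carboxy-1-methylbutyl in place of 4-carboxy-2-methylbutyl on an aromatic carbon. The methyl thus shifts along the chain while the acid and the chain length stay as they are. Within the data shown here, no measured step bears on this kind of change, since the step from compound 1 to compound 3 concerns the acid group rather than the methyl position, and compound 2 differs from both in more than one place. A step of no more than the scatter is therefore expected in this assay, no change at the digits printed from compound 3 to compound 4 (within the scatter). Compound 4 is estimated at 140 nM, within a range from 50 nM to 400 nM.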

Compound 4, inhibition constant: 90 nM
Beside the measured number, compound 4's estimate is 1.6-fold (0.19 log units) above it; measured number inside the range.
By their numbers in this assay, from the lowest: compound 1; then compounds 4, 2 and 3 (each within the scatter of the next).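

In this assay the step of a 1.6-fold lower number from compound 3 to compound 4 (0.19 log units; within the scatter) shows that moving the methyl, with 4-carboxy-1-methylbutyl in place of 4-carboxy-2-methylbutyl on the aromatic carbon, cannot be told apart from no change. Within the data shown here, the earlier compounds offered only the exchange of the acid-bearing group, the step of an 8.2-fold higher number from compound 1 to compound 3 (0.92 log units; beyond the scatter) beyond the scatter, so this pair is the first to isolate the methyl's place on the chain while the acid and the chain's atoms stay the same, and here that place makes no readable difference. The compounds shown carry no information that would account for this result.

Among these compounds, it remains open whether the methyl's place would matter with a different acid-bearing end, such as a 1H-tetrazol-5-yl group in place of the carboxylic acid on the 4-carboxy-1-methylbutyl chain, since only compound 1 carries that group and its chain differs from the one in compound 4 in more than the methyl's place. Also open, going by these compounds, is what an ethyl group in place of the methyl, a chain with no methyl at all, or a longer chain would give.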